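A bromo to iodo exchange, not yet measured

This account rests on a few compounds, and the source may have more. Where it says the series, first, only, none or still open, it means among the compounds named here.

Within the data shown here, in a functional assay on CCRF-CEM cells (Homo sapiens) (on this read-out lower numbers stand for higher toxicity in this test and higher numbers for lower toxicity in this test), compound 1 `Cc1cn([C@@H]2O[C@H](CO[Si](C)(C)C(C)(C)C)[C@@]3(OS(=O)(=O)C(Br)=C3N)[C@H]2O[Si](C)(C)C(C)(C)C)c(=O)[nH]c1=O` gives 17000 nM on the numbers so far. Compound 3 `CC1=C(N)[C@@]2(OS1(=O)=O)[C@@H](CO[Si](C)(C)C(C)(C)C)O[C@@H](n1cc(C)c(=O)n(C)c1=O)[C@@H]2O[Si](C)(C)C(C)(C)C` gives 10000 nM and so lies within the usual scatter of compound 1. Compound 2 `CNC1=C(C)S(=O)(=O)O[C@@]12[C@@H](CO[Si](C)(C)C(C)(C)C)O[C@@H](n1cc(C)c(=O)n(C)c1=O)[C@@H]2O[Si](C)(C)C(C)(C)C` gives 234000 nM and stands well above both.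

Compound 4 `Cc1cn([C@@H]2O[C@H](CO[Si](C)(C)C(C)(C)C)[C@@]3(OS(=O)(=O)C(I)=C3N)[C@H]2O[Si](C)(C)C(C)(C)C)c(=O)[nH]c1=O` differs from compound 1 in one place, on a double-bonded ring carbon, next to the ring sulfur. The change in counts is iodo in place of bromo on a double-bonded ring carbon and nothing else in the structure moves.

Among the measured compounds shown here, the only measured step is a 23-fold lower number from compound 2 to compound 3 (1.37 log units; beyond the scatter) and it is large, but it concerns hydrogen in place of methyl on an amine nitrogen. For the measured compounds named here, it shows that one small change can move the number far in this set, yet no measured pair exchanges one halogen for another. No step beyond the scatter is therefore expected in this assay in either direction. The estimated step is a 1.1-fold lower number from compound 1 to compound 4 (0.05 log units; within the scatter) and it is expected to stay within the scatter. Compound 4 is expected near 15000 nM with an estimated range from 6000 nM to 40000 nM in this test.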

Compound 4, half-maximal cytotoxic concentration: 4000 nM
Beside the measured number, compound 4's estimate is 3.8-fold (0.57 log units) above it, and the stated range ends above it.
By their numbers in this assay, from the lowest: compound 4; then compounds 3 and 1 (each within the scatter of the next); then compound 2.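

In this assay, the group on the double-bonded ring carbon next to the ring sulfur proves able to shift the number: iodo in place of bromo gives a 4.3-fold lower number from compound 1 to compound 4 (0.63 log units; beyond the scatter), a modest step but one beyond the scatter. Among these compounds, this is the first measured sign that exchanging one halogen for another at this position matters, even though a single heavy atom is swapped and the counts of hydrogen-bond donors and acceptors stay the same. No available evidence bears on what lies behind this step.

With only bromo and iodo shown on this carbon, it remains open how chloro, a plain hydrogen or a nitrile would compare there. Going by these compounds, it is also open whether iodo would give a lower number than bromo in other cell lines.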